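This account rests on a few compounds, and the source may have more. Where it says the series, first, only, none or still open, it means among the compounds named here.

Compound 1 `CC(C)=CCOc1ccc2c(c1)OC(c1ccc(C)cc1)CC2=O`: in a functional assay (on this read-out higher numbers stand for weaker inhibition and lower numbers for stronger inhibition), compound 1 gives 4440 nM.
Compound 2 `COc1ccc(C2CC(=O)c3ccc(OCC=C(C)C)cc3O2)cc1`: in this assay compound 2 gives 10200 nM.
Compound 3 `COc1ccc(C2CC(=O)c3ccc(OCC=C(C)C)cc3O2)c(OC)c1`: in this assay compound 3 gives 8180 nM.

Compound 2 has the highest number of the three. Its step to compound 3 lies within the scatter, while compound 1 sits clearly lower, as the change a 2.3-fold higher number from compound 1 to compound 2 (0.36 log units; beyond the scatter) shows. Compound 4 `COc1ccc(C2CC(=O)c3c(O)cc(OCC=C(C)C)cc3O2)cc1` differs from compound 2 by hydroxy in place of hydrogen on an aromatic carbon. For the measured compounds named here, no measured step adds a group on this ring; the steps that exist, a 2.3-fold higher number from compound 1 to compound 2 (0.36 log units; beyond the scatter) and a 1.2-fold lower number from compound 2 to compound 3 (0.10 log units; within the scatter), concern the other ring and were modest or within the scatter. So for compound 4 a step of about a 1.3-fold lower number from compound 2 to compound 4 (0.11 log units; within the scatter) in this assay is expected, with no firm direction. The expected value for compound 4 is 8000 nM, between 3000 nM and 25000 nM.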

Compound 4, half-maximal inhibitory concentration: 5080 nM
Beside the measured number, compound 4's estimate is 1.6-fold (0.20 log units) above it, and the stated range covers the measured number.
By their numbers in this assay, from the lowest: compounds 1, 4, 3 and 2 (each within the scatter of the next, the first and the last beyond it).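

For the compounds shown here, the first change on this ring of the shared core, hydroxy in place of hydrogen ortho to a fused ring, gives a 2.0-fold lower number from compound 2 to compound 4 (0.30 log units; within the scatter) in this assay. This position therefore accepts a hydroxy group without a measurable loss of inhibition, though no firm gain can be claimed either. Nothing available explains this step. The compounds shown leave open how an amine or a fluorine atom would read at this position. They also leave open whether hydroxy here would give a similar step on compound 1 or compound 3.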